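This account rests on a few compounds, and the source may have more. Where it says the series, first, only, none or still open, it means among the compounds named here.

Measured in a functional assay on HT-29 cells (Homo sapiens) for inhibition, read by MTT assay, with a stated time of 48 h; on this read-out higher numbers stand for weaker inhibition and lower numbers for stronger inhibition:
Compound 1 `COc1ccc(-n2c(SCc3ccc(C)cc3)nnc2-c2cc(OC)c(OC)c(OC)c2)cc1`: > 60000 nM, which is a limit.
Compound 2 `COc1ccc(-n2c(SCC(=O)Nc3ccc(Cl)cc3)nnc2-c2cc(OC)c(OC)c(OC)c2)cc1`: 58000 nM.
Compound 3 `COc1cc(-c2nnc(SCc3ccc(C)cc3)n2-c2ccc(N(C)C)cc2)cc(OC)c1OC`: 27500 nM.

Compound 3, at 27500 nM, has the lower of the two true numbers, and compound 2 lies nearest to it. Compound 4 `COc1cc(-c2nnc(SCC(=O)C3CC3)n2-c2ccc(N(C)C)cc2)cc(OC)c1OC` follows from compound 3 by one change: cyclopropylcarbonyl in place of 4-methylphenyl on a saturated chain carbon bound to a sulfur. It places cyclopropylcarbonyl in place of 4-methylphenyl on a saturated chain carbon bound to a sulfur. Among the measured compounds shown here, the only measured change at that place is an at least 1.0-fold lower number from compound 1 to compound 2 (0.01 log units; that floor lies within the scatter), and it starts from a limit. The other measured change, an at least 2.1-fold lower number from compound 1 to compound 3 (0.33 log units; beyond the scatter), brought in the dimethylamino that compound 4 keeps. Little movement is therefore expected, with no clear direction. The expected change is a 1.1-fold higher number from compound 3 to compound 4 (0.04 log units; within the scatter). Compound 4 is estimated at 30000 nM, within an expected range of 9000 nM to 60000 nM.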

Compound 4, half-maximal inhibitory concentration: > 60000 nM
Compound 4 was reported as a limit; the forecaster's own chance of this, stated with the estimate: 20%; at least 2.0-fold (0.30 log units) between middle value and limit.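

With the dimethylamino kept, cyclopropylcarbonyl in place of 4-methylphenyl on a saturated chain carbon bound to a sulfur gives, in this assay, an at least 2.1-fold higher number from compound 3 to compound 4 (0.33 log units; beyond the scatter), so inhibition weakens and this place moves the read-out beyond the scatter, which the earlier step there did not show. Compound 4 gives > 60000 nM, which is a limit. The step is only a floor, and its full size stays unknown because of that limit: the limit of > 60000 nM in this assay, at which 2 of the 4 values shown sit.

Open, going by these compounds, is whether an amine, a carboxylic acid or a longer chain at this place would strengthen inhibition beyond compound 3. Also open, on these data alone, is how (4-chlorophenyl)carbamoyl behaves alongside the dimethylamino.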